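The source may hold more compounds than are shown below. What is called first, only, known or untested is meant among the compounds shown, and "the series" means these compounds.

The measured compounds: compound 1, `CC1(C)N=C(N)N=C(N)N1c1cccc(C(O)c2ccccc2)c1`, which in a functional assay on L5178Y cells (Mus musculus) (on this read-out lower numbers stand for lower potency and higher numbers for higher potency (the scale is a negative logarithm)), gives 4.17; compound 2, `CCCCCCCCCOc1cccc(N2C(N)=NC(N)=NC2(C)C)c1`, which in this assay gives 6.57.

Compound 2 stands highest of these two numbers; its nearest neighbour is compound 1, whose value lies lower by a margin beyond the usual scatter. Compound 3, `CCCCCCCCCCCCOc1cccc(N2C(N)=NC(N)=NC2(C)C)c1`, has not yet been measured. It differs from compound 2 by propyl in place of hydrogen on a saturated chain carbon, nine bonds along the chain from an oxygen on an aromatic ring. Going by the values given here, no step between measured compounds shows how such a change acts, so the expectation rests on compound 2 and its value 6.57 alone. A small rise, a number 0.23 log units higher from compound 2 to compound 3 (within the scatter), is expected rather than a fall. Compound 3 is estimated at 6.8, between 6.2 and 7.4.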

Compound 3, logarithm of the reciprocal of the active concentration, log(1/C): 6.24
Compound 3: the middle estimate sits 0.56 log units above what was measured; the measured number falls inside the stated range.
By their numbers in this assay, from the lowest: compound 1; then compound 3; then compound 2.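

In this assay, the step with propyl in place of hydrogen on a saturated chain carbon, nine bonds along the chain from an oxygen on an aromatic ring, is a number 0.33 log units lower from compound 2 to compound 3 (beyond the scatter). It shows that at this position, extending the chain by this much lowers the number modestly rather than raising it. Nothing at hand explains this step. On these data alone, whether a shorter extension with ethyl, or a chain ending in an amine or a carboxylic acid, would match compound 2 stays open. So does the effect of a longer chain.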